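This account rests on a few compounds, and the source may have more. Where it says the series, first, only, none or still open, it means among the compounds named here.

Measured compounds:
compound 1, `C[C@H]1[C@H](NCc2sccc2C2CCCC2)C[C@H]2C[C@@H]1C2(C)C`: 12500 nM
compound 2, `C[C@H]1[C@H](NCc2sccc2C2CC2)C[C@H]2C[C@@H]1C2(C)C`: 25000 nM
compound 3, `C[C@H]1[C@H](NCc2ccco2)C[C@H]2C[C@@H]1C2(C)C`: 50000 nM

These numbers come from an ADME assay on MDCK cells (Canis lupus familiaris) for cytotoxicity, read by microscopy, with a stated time of 48 h; on this read-out higher numbers stand for lower toxicity in this test and lower numbers for higher toxicity in this test. Compound 3 shows the highest of the three numbers; its gap to compound 2 is within the scatter, while compound 1 lies beyond it. Compound 4, `C[C@H]1[C@H](NCc2sccc2Br)C[C@H]2C[C@@H]1C2(C)C`, is not yet measured. Relative to compound 3 the change is 3-bromothiophen-2-yl in place of furan-2-yl on a saturated chain carbon bound to an amine nitrogen. Among the measured compounds shown here, the only measured step, a 2.0-fold higher number from compound 1 to compound 2 (0.30 log units; within the scatter), alters a group on a thiophene ring and stays within the scatter; no measured step exchanges one aromatic ring for another. Compounds 1 and 2 both carry a thiophene ring, and the number for compound 1 falls beyond the scatter below that of compound 3. A step of about a 2.0-fold lower number from compound 3 to compound 4 (0.30 log units; within the scatter) is therefore expected, toward a lower number. Compound 4 is estimated at 25000 nM, with a range from 10000 nM to 60000 nM.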

Compound 4, minimum cytotoxic concentration: 50000 nM
Compound 4: middle estimate off by 2.0-fold (0.30 log units), on the low side; the range from low to high includes it.
By their numbers in this assay, from the lowest: compounds 1, 2, 3 and 4 (each within the scatter of the next, the first and the last beyond it).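

In this assay the step of no change at the digits printed from compound 3 to compound 4 (within the scatter) is the only one shown that exchanges one aromatic ring for another, and at this place on the saturated chain carbon, 3-bromothiophen-2-yl reads the same as furan-2-yl. Bromo in place of cyclopropyl gives a 2.0-fold higher number from compound 2 to compound 4 (0.30 log units; within the scatter) and stays within the scatter, whereas bromo in place of cyclopentyl gives a 4.0-fold higher number from compound 1 to compound 4 (0.60 log units; beyond the scatter) and is a modest step. No evidence here explains these results.

The compounds shown leave open how an amine or a carboxylic acid in place of bromo on that aromatic carbon would read, and whether the thiophene ring without bromo would match furan-2-yl.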